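A few compounds are considered here, and "the series" means these few. Any claim that something is new, unique, unknown or untested is made for them only; others in the source may bear on it.

Measured in a functional assay on HepG2 cells (Homo sapiens) for inhibition, read by MTT assay, with a stated time of 72 h; on this read-out lower numbers stand for stronger inhibition and higher numbers for weaker inhibition:
- compound 1 `Cc1cc2occ(-c3nc(-c4ccccc4)c(-c4ccccc4)n3-c3ccc([N+](=O)[O-])cc3)c(=O)c2cc1Cl`: 25000 nM
- compound 2 `COc1ccccc1-n1c(-c2coc3cc(C)c(Cl)cc3c2=O)nc(-c2ccccc2)c1-c1ccccc1`: 12500 nM

Compound 2 gives 12500 nM, and this value lies within the scatter of the value for compound 1, so the two compounds cannot be ranked. Compound 3 `Cc1cc2occ(-c3nc(-c4ccccc4)c(-c4ccccc4)n3-c3ccc(Cl)c(Cl)c3)c(=O)c2cc1Cl` carries 3,4-dichlorophenyl in place of 2-methoxyphenyl on an aromatic nitrogen. That nitrogen belongs to a five-membered aromatic ring with 2 nitrogen.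

Within the data shown here, one measured step bears on this change, as it exchanges the group on the same nitrogen: a 2.0-fold lower number from compound 1 to compound 2 (0.30 log units; within the scatter). This is a single step, and it stays within the scatter. Neither measured compound carries 3,4-dichlorophenyl, so the data do not test this group directly, and the range is kept wide. No step beyond the scatter is therefore expected in this assay. The estimated change is a 1.1-fold higher number from compound 2 to compound 3 (0.05 log units; within the scatter). Compound 3 is expected at 14000 nM, with an estimated range of 5000 nM to 40000 nM.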

Compound 3, half-maximal inhibitory concentration: 12500 nM
Compound 3: the middle estimate sits 1.1-fold (0.05 log units) above what was measured; low and high end bracket the measured number.
By their numbers in this assay, from the lowest: compounds 2, 3 and 1 (each within the scatter of the next).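

In this assay, the group on the aromatic nitrogen now has a third form, and 3,4-dichlorophenyl in place of 2-methoxyphenyl gives no change at the digits printed from compound 2 to compound 3 (within the scatter), while the same group in place of 4-nitrophenyl gives a 2.0-fold lower number from compound 1 to compound 3 (0.30 log units; within the scatter). The first of these exchanges removes the oxygen and hydrogen-bond acceptor of 2-methoxyphenyl and brings in chlorine at the same heavy-atom count, yet the number stays within the scatter, so across compounds 1, 2 and 3 this position shows no measurable response to the choice among these three substituted phenyl groups. No supporting measurement bears on this flat result.

Open, on these data alone, is whether a substituent of a different kind on this nitrogen, such as a phenyl ring carrying an amine or a carboxylic acid, or a longer alkyl chain in place of the ring, would move the number beyond the scatter. As far as these compounds go, compounds 1, 2 and 3 also share the rest of the core, including both phenyl groups on the five-membered ring, so what those parts contribute to the values in this assay remains unknown.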